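Swapping a hydroxyethyl for a nitrophenyl on the sulfonamide

The compounds below may be only part of what the source reports. "The series", "measured", "known", "first", "only" and "open" are said of these compounds alone.

Compound 2 `CC1(C)C=C(n2ccccc2=O)c2cc(S(=O)(=O)NCCO)ccc2O1` gives 95.5% in a functional assay on the whole organism (aorta) with Rattus norvegicus as the target; on this read-out lower numbers stand for smaller maximal responses and higher numbers for larger maximal responses. Compound 1 `CC1(C)C=C(n2ccccc2=O)c2cc(S(=O)(=O)N=[N+]=[N-])ccc2O1` gives 88.3% in this assay, and the step of a number 7.2 percentage points higher from compound 1 to compound 2 (within the scatter) leaves the two within the scatter, so compound 2 sits at the upper end of the two single numbers without standing apart from compound 1. Compound 3 `CC1(C)C=C(n2ccccc2=O)c2cc(S(=O)(=O)Nc3ccccc3)ccc2O1` gives 63.6%; 82.5% (2 entries) in this assay; its repeated entries the several entries of compound 3 in this assay, 63.6%; 82.5% (2 entries) show how far one compound can scatter, and both of its numbers fall below that of compound 2. Compound 4 `CC1(C)C=C(n2ccccc2=O)c2cc(S(=O)(=O)Nc3ccc([N+](=O)[O-])cc3)ccc2O1` differs from compound 2 by 4-nitrophenyl in place of 2-hydroxyethyl on a sulfonamide nitrogen. Among the measured compounds shown here, no measured step covers this change; the nearest guide is compound 3. Compound 4 is therefore expected to give a somewhat smaller maximal response, a step of a number 20.5 percentage points lower from compound 2 to compound 4 (beyond the scatter). The estimate for compound 4 is 75%, with a range from 55% to 95%.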

Compound 4, largest response reached (Emax), in percent of the reference or control that the assay uses: 82.2%
For compound 4 the middle estimate is 7.2 percentage points below the measured one, within the range that was stated.
By their numbers in this assay, from the lowest: compounds 4, 1 and 2 (each within the scatter of the next, the first and the last beyond it).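

In this assay there is a number 13.3 percentage points lower from compound 2 to compound 4 (beyond the scatter) when 4-nitrophenyl replaces 2-hydroxyethyl on the sulfonamide nitrogen, so a large aromatic group here costs only a modest part of the maximal response. The second comparison, a number 6.1 percentage points lower from compound 1 to compound 4 (within the scatter) with (4-nitrophenyl)amino in place of azido, shows no real separation. The modest step also needs caution, as compound 4 falls inside the span of a single compound: the several entries of compound 3 in this assay, 63.6%; 82.5% (2 entries). From the compounds shown here alone, how an amine, a carboxylic acid or a longer chain on this nitrogen would behave remains open.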